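A few compounds are considered here, and "the series" means these few. Any claim that something is new, unique, unknown or untested is made for them only; others in the source may bear on it.

Compound 1 `O=C(Nc1cccc(Oc2ccccn2)c1)C1CCCN(C(=O)c2cc(C(F)(F)F)cc(C(F)(F)F)c2)C1` shows no inhibition in an ADME assay on PC-3 cells (Homo sapiens) for cytotoxicity, read by WST assay, tested at 100 uM; a lower number here means less inhibition, a higher number more inhibition at the concentration tested (going by the name of the read-out): compound 1 gives 0%. Compound 2 `O=C(Nc1cccc(Oc2ccccc2)c1)C1CCCN(C(=O)c2cccc(-c3ccco3)c2)C1` stands level with it there, giving 0% in this assay. Compound 3 `O=C(Nc1cccc(OCCc2ccccn2)c1)C1CCCN(C(=O)c2cc(C(F)(F)F)cc(C(F)(F)F)c2)C1` is the compound still to be measured, and it differs from compound 1 in one place: 2-(pyridin-2-yl)ethyl in place of pyridin-2-yl on an oxygen on an aromatic ring. Among the compounds with values here, no step between measured compounds is available, and both values sit at the floor of the read-out, so the expectation for this assay is a step of no change at the digits printed from compound 1 to compound 3 (within the scatter), none beyond the scatter. For compound 3 the estimate in this assay is 0%, with a range from 0% to 10%.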

Compound 3, a percentage reported as inhibition, at one concentration (the size of the read-out at that concentration, not a potency): 5%
For compound 3 the middle estimate is 5 percentage points below the measured one, within the range that was stated.
By their numbers in this assay, from the lowest: compounds 1, 2 and 3 (each within the scatter of the next).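

Placing 2-(pyridin-2-yl)ethyl in place of pyridin-2-yl on an oxygen on an aromatic ring provides the first single-place comparison at this position: in this assay the change gives a number 5 percentage points higher from compound 1 to compound 3 (within the scatter). At this position, the 2-(pyridin-2-yl)ethyl group is therefore carried without a step beyond the scatter. Nothing available accounts for this result.

The compounds shown leave open whether a longer chain in place of the ethyl, or an amine or a carboxylic acid in place of the pyridin-2-yl, would stay within the scatter.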